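Notes on the step to 3,4-dimethylphenyl

The source may report more compounds than this note shows. Statements on the series, on what has been measured and on what is new or still open speak of the compounds shown alone.

Measured so far in a functional assay on KBVIN cells (Homo sapiens) for antiproliferative activity, read by sulforhodamine B assay, with a stated time of 3 days; a lower number here means that less compound is needed, a higher number that more compound is needed for the effect
- compound 1 `CCCc1ccc(-c2cc(=O)c3c(o2)C(CC)(CC)C(=O)C(CC)=C3O)cc1` gives 12.2 uM
- compound 2 `CCC1=C(O)c2c(oc(-c3ccc(COC)cc3)cc2=O)C(CC)(CC)C1=O` gives 3.4 uM
- compound 3 `CCC1=C(O)c2c(oc(-c3cccc(C)c3)cc2=O)C(CC)(CC)C1=O` gives 3.69 uM

Compound 3 stands level with compound 2, with a 1.1-fold higher number from compound 2 to compound 3 (0.04 log units; within the scatter) as the gap, while the comparison with the remaining compound shows a 3.3-fold lower number from compound 1 to compound 3 (0.52 log units; beyond the scatter) as a modest move. Compound 4 `CCC1=C(O)c2c(oc(-c3ccc(C)c(C)c3)cc2=O)C(CC)(CC)C1=O` differs from compound 3 by methyl in place of hydrogen on an aromatic carbon and so turns 3-methylphenyl into 3,4-dimethylphenyl, with methyl in place of hydrogen on an aromatic carbon.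

Among the measured compounds shown here, no measured step adds a methyl on its own, so the evidence is indirect. Compound 1 with 4-propylphenyl and compound 2 with 4-(methoxymethyl)phenyl are separated by a 3.6-fold lower number from compound 1 to compound 2 (0.55 log units; beyond the scatter) as a modest step, so a change on the far end of that group can move the number. Yet compound 2 stays within the scatter of compound 3, and the incoming methyl is much shorter than propyl. In this assay no step beyond the scatter is therefore expected, with some risk of an upward drift toward compound 1. The estimate amounts to a 1.0-fold higher number from compound 3 to compound 4 (0.01 log units; within the scatter) as the expected step. For compound 4 the expected value is 3.8 uM and 1.7 uM to 8.5 uM is the estimated range.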

Compound 4, concentration for half-maximal effect: 0.71 uM
Compound 4: the middle estimate sits 5.4-fold (0.73 log units) above what was measured; the whole stated range lies above it.
By their numbers in this assay, from the lowest: compound 4; then compounds 2 and 3 (each within the scatter of the next); then compound 1.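

Methyl in place of hydrogen on an aromatic carbon, ortho to a methyl group and para to a large group, gives a 5.2-fold lower number from compound 3 to compound 4 (0.72 log units; beyond the scatter) in this assay, so one added heavy atom at this position moves the number beyond the scatter, which no earlier compound could show. The level standing of 3-methylphenyl and 4-(methoxymethyl)phenyl does not extend to 3,4-dimethylphenyl: the comparison with the latter group reads a 4.8-fold lower number from compound 2 to compound 4 (0.68 log units; beyond the scatter), and that with 4-propylphenyl reads a 17-fold lower number from compound 1 to compound 4 (1.24 log units; beyond the scatter), which leaves compound 4 with the lowest number of the four. Nothing measured here accounts for the size of this step.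

The compounds shown leave open whether the incoming methyl needs the methyl already on the ring, as 3,4-dimethylphenyl is the only aryl group here carrying two substituents, and a ring with a lone methyl on the same carbon would separate the two readings. Also open, from the compounds shown here alone, is how an ethyl, a methoxy or a chlorine on that carbon would read in this assay, which would show whether the step is particular to methyl.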